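The source may hold more compounds than are shown below. What is called first, only, known or untested is meant among the compounds shown, and "the series" means these compounds.

In a physicochemical assay for solubility, read by HPLC, in phosphate buffer, measured as kinetic solubility, at pH 7.4 (on this read-out lower numbers stand for lower solubility and higher numbers for higher solubility), compound 1 (`Cc1ccc(-c2ccc(Cl)cc2)n1-c1ccc(S(N)(=O)=O)cc1`) gives 6100 nM and compound 3 (`CCOC(=O)c1cc(-c2ccc(Cl)cc2)n(-c2ccc(S(N)(=O)=O)cc2)c1C`) gives 4200 nM, two values within the scatter of each other, while compound 2 (`CC(=O)c1cc(-c2ccc(Cl)cc2)n(-c2ccc(S(N)(=O)=O)cc2)c1C`) gives 2700 nM and stands apart from compound 1 beyond the scatter. Compound 4 (`CCC(=O)c1cc(C)n(-c2ccc(S(N)(=O)=O)cc2)c1-c1ccc(Cl)cc1`) has not yet been measured. It differs from compound 1 by propanoyl in place of hydrogen on an aromatic carbon, next to the ring atom that bears a 4-chlorophenyl group. Within the data shown here, two measured steps bear on this change: acetyl in place of hydrogen gave a 2.3-fold lower number from compound 1 to compound 2 (0.35 log units; beyond the scatter) and ethoxycarbonyl in place of hydrogen gave a 1.5-fold lower number from compound 1 to compound 3 (0.16 log units; within the scatter), and the two groups themselves differ by a 1.6-fold higher number from compound 2 to compound 3 (0.19 log units; within the scatter) as their gap. Neither group stands where the propanoyl of compound 4 stands, so these steps guide only loosely. A modest step to a lower number is therefore expected in this assay, close in size to the acetyl step. Compound 4 is estimated at 2800 nM with an expected range from 1200 nM to 5800 nM as its likely span. The expected step is a 2.2-fold lower number from compound 1 to compound 4 (0.34 log units; beyond the scatter) and it remains an estimate.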

Compound 4, solubility: 6900 nM
Compound 4: middle estimate off by 2.5-fold (0.39 log units), on the low side; the whole stated range lies below it.
By their numbers in this assay, from the lowest: compounds 2, 3, 1 and 4 (each within the scatter of the next, the first and the last beyond it).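

In this assay, propanoyl in place of hydrogen on this aromatic carbon, next to the ring atom that bears a 4-chlorophenyl group, gives a 1.1-fold higher number from compound 1 to compound 4 (0.05 log units; within the scatter), so this change leaves the two compounds within the scatter of each other. Among these compounds, the acetyl change, which gave a 2.3-fold lower number from compound 1 to compound 2 (0.35 log units; beyond the scatter), sits at a different place on the ring, so the earlier steps did not show what a carbonyl-bearing chain does at this carbon, and this one step shows that such a chain need not move the number beyond the scatter. Nothing measured here explains this result.

The compounds shown leave open whether an amine, a carboxylic acid or a longer chain at this same carbon would also stay within the scatter of compound 1. They also leave open whether acetyl or ethoxycarbonyl would behave as propanoyl does at this carbon.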